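Replacing a Methoxyphenyl Group with a Hydroxynaphthyl Group

A few compounds are considered here, and "the series" means these few. Any claim that something is new, unique, unknown or untested is made for them only; others in the source may bear on it.

Measured so far:
Compound 1, `Cc1ccc(C2C(C#N)=C(N)N(c3ccc(S(N)(=O)=O)cc3)C3=C2C(=O)CCC3)cc1`, gives 30% in a functional assay on Ehrlich cells (Mus musculus) for antiproliferative activity, read by trypan blue exclusion, with a stated time of 2 h, tested at 10 ug/mL; a lower number here means a weaker effect, a higher number a stronger effect of the compound at the concentration tested.
Compound 2, `N#CC1=C(N)N(c2ccc(S(N)(=O)=O)cc2)C2=C(C(=O)CCC2)C1/C=C/c1ccccc1`, gives 2% in this assay.
Compound 3, `COc1ccc(C2C(C#N)=C(N)N(c3ccc(S(N)(=O)=O)cc3)C3=C2C(=O)CCC3)cc1`, gives 30% in this assay.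

Compound 3 stands level with compound 1 at the digits shown, and the two together hold the highest of the three numbers; compound 2 lies well below, a number 28 percentage points higher from compound 2 to compound 3 (beyond the scatter) when read towards compound 3.

Compound 4, `N#CC1=C(N)N(c2ccc(S(N)(=O)=O)cc2)C2=C(C(=O)CCC2)C1c1c(O)ccc2ccccc12`, differs from compound 3 at the saturated ring carbon: 2-hydroxynaphthalen-1-yl in place of 4-methoxyphenyl on a saturated ring carbon.

Two kinds of step inform the expectation. Changing a group on the aromatic ring left the number untouched, no change at the digits printed from compound 1 to compound 3 (within the scatter). Replacing the aromatic ring itself with a 2-phenylethenyl group lowered it clearly, a number 28 percentage points lower from compound 1 to compound 2 (beyond the scatter). Compound 4 keeps an aromatic ring directly on that carbon, so the small tolerated step seems the closer guide, though a second fused ring and a hydroxy group are new and untested here. The step to compound 4 is therefore expected to be small, a number 3 percentage points lower from compound 3 to compound 4 (within the scatter), within or near the scatter.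

Compound 4 is estimated at 27%, in the range 10% to 45%.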

Compound 4, a percentage reported as activity, at one concentration (the size of the read-out at that concentration, not a potency): 0%
Estimate against measurement, compound 4: 27 percentage points above; measured number outside the range, below it.
By their numbers in this assay, from the lowest: compounds 4 and 2 (each within the scatter of the next); then compounds 1 and 3 (each within the scatter of the next).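

In this assay, keeping an aromatic ring directly on the saturated ring carbon does not by itself preserve the read-out: 2-hydroxynaphthalen-1-yl in place of 4-methoxyphenyl gives a number 30 percentage points lower from compound 3 to compound 4 (beyond the scatter) and, in place of 4-methylphenyl, gives a number 30 percentage points lower from compound 1 to compound 4 (beyond the scatter) as well. Set against the 2-phenylethenyl group, the same change gives a number 2 percentage points lower from compound 2 to compound 4 (within the scatter) and so shows that this position tolerates the two small substituted phenyl groups but not either of these two larger replacements. No measurement is available that offers a reason for this loss.

The second fused ring and the hydroxy group enter together, so their separate contributions cannot be told apart. A plain naphthyl group and a hydroxyphenyl group at this carbon would address that question.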